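The compounds below may be only part of what the source reports. "The series", "measured", "known", "first", "only" and "open" are said of these compounds alone.

Within the data shown here, compound 1 `CCN(CC)C(=O)CN(c1cc(N(CC)CC)ccc1Cl)S(=O)(=O)c1ccc(OC)c(OC)c1` is one of the two measured members. In a functional assay on CHO cells for inhibition of Orexin/Hypocretin receptor type 1 (Homo sapiens), read by FLIPR and calcium flux (on this read-out higher numbers stand for weaker inhibition and lower numbers for stronger inhibition), compound 1 reaches only a limit of the assay, > 10000 nM. Compound 2 `CCN(CC)C(=O)CN(c1ccc(C)cc1)S(=O)(=O)c1cccc(F)c1` likewise gives only a limit in this assay, > 10000 nM. Where compound 2 stands is thus fixed by the limit of > 10000 nM in this assay, at which 2 of the 2 values shown sit, with no numbered value in the set. Compound 3 `CCN(CC)C(=O)CN(c1ccc(C)cc1)S(=O)(=O)c1ccc(OC)cc1` is the unmeasured analogue, differing by 4-methoxyphenyl in place of 3-fluorophenyl on a sulfonyl sulfur, a 4-methoxyphenyl in place of 3-fluorophenyl on a sulfonyl sulfur. Among the measured compounds shown here, no measured step exists, so no size or direction beyond the scatter is known. Compound 3 is expected at 20000 nM, within 5000 nM to 80000 nM. The expected step is a step that the limit leaves unreadable from compound 2 to compound 3, most likely again a limit.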

Compound 3, half-maximal inhibitory concentration: > 10000 nM
Compound 3: only a limit was reported; the forecaster's own chance of this, stated with the estimate: 85%; the middle value is on the limit's open side.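

Compound 2 and compound 3 both give only a limit, so no step can be read for 4-methoxyphenyl in place of 3-fluorophenyl on the sulfonyl sulfur. The compounds shown leave open whether any change to the shared core gives a numbered value.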